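Replacing One Methoxy Group in Compound 2 with Hydrogen

The source may hold more compounds than are shown below. What is called first, only, known or untested is meant among the compounds shown, and "the series" means these compounds.

In a functional assay on a cell-free system (plasma, Homo sapiens) for inhibition (a lower number here means a stronger inhibitor, a higher number a weaker inhibitor), compound 2 `COc1ccc(/C=C/C(=O)Nc2nccs2)cc1OC` gives 54500 nM and compound 1 `CC(=O)Oc1ccc(/C=C/C(=O)Nc2nccs2)cc1` gives 58100 nM, so the two values lie within the scatter of each other. Compound 3 `COc1ccc(/C=C/C(=O)Nc2nccs2)cc1` differs from compound 2 by having hydrogen in place of methoxy on an aromatic carbon, ortho to a methoxy group (hydrogen in place of methoxy on an aromatic carbon). Going by the values given here, no measured pair of compounds isolates this change, so the data give no direct measure of its size. With only compound 1 at 58100 nM and compound 2 at 54500 nM to go on, no shift beyond the scatter is expected in this assay, and neither direction is favoured. The expected change is a 1.1-fold lower number from compound 2 to compound 3 (0.04 log units; within the scatter). Compound 3 is estimated at 50000 nM, with an expected range of 25000 nM to 100000 nM.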

Compound 3, half-maximal inhibitory concentration: 73700 nM
Compound 3: the middle estimate sits 1.5-fold (0.17 log units) below what was measured; the measured number falls inside the stated range.
By their numbers in this assay, from the lowest: compounds 2, 1 and 3 (each within the scatter of the next).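

In this assay, hydrogen in place of the methoxy group ortho to a methoxy group gives a 1.4-fold higher number from compound 2 to compound 3 (0.13 log units; within the scatter) and this step lies within the scatter, so the data separate neither group from the other at this position. Methyl in place of acetyl on the oxygen on the aromatic ring gives a 1.3-fold higher number from compound 1 to compound 3 (0.10 log units; within the scatter) and this step also lies within the scatter, so the two single changes shown leave all three compounds indistinguishable in this measurement. No other information bears on this result or accounts for it.

On these data alone, it remains open whether a different group at this position, such as a hydroxyl, an amine or a carboxylic acid, would move the number beyond the scatter. As far as these compounds go, it also remains open whether a change elsewhere on the shared core would do so.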